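Replacing trimethoxyphenyl with bromophenyl on the shared core

This account rests on a few compounds, and the source may have more. Where it says the series, first, only, none or still open, it means among the compounds named here.

Compound 3 `COc1cc(-c2nc(SCc3cn(Cc4ccccc4Cl)nn3)nc(Nc3ccc(C)cc3)c2C#N)cc(OC)c1OC` gives the highest number of the three measured in a functional assay on B16-F10 cells (Mus musculus) for inhibition, read by MTT assay, with a stated time of 72 h (on this read-out lower numbers stand for stronger inhibition and higher numbers for weaker inhibition), at 20300 nM. Compound 1 `Cc1ccc(Nc2nc(SCc3cn(Cc4ccccc4Cl)nn3)nc(-c3ccccc3)c2C#N)cc1` gives 3390 nM and compound 2 `Cc1ccc(Nc2nc(SCc3cn(Cc4ccccc4Cl)nn3)nc(-c3ccc(C(C)C)cc3)c2C#N)cc1` gives 3530 nM; the steps of a 6.0-fold higher number from compound 1 to compound 3 (0.78 log units; beyond the scatter) and a 5.8-fold higher number from compound 2 to compound 3 (0.76 log units; beyond the scatter) both run beyond the scatter, while a 1.0-fold higher number from compound 1 to compound 2 (0.02 log units; within the scatter) does not. Compound 4 `Cc1ccc(Nc2nc(SCc3cn(Cc4ccccc4Cl)nn3)nc(-c3ccc(Br)cc3)c2C#N)cc1` carries the change (4-bromophenyl in place of 3,4,5-trimethoxyphenyl on an aromatic carbon). A 4-bromophenyl is more like the phenyl of compound 1 and the 4-isopropylphenyl of compound 2 than like the 3,4,5-trimethoxyphenyl of compound 3, so the step from compound 3 is expected to undo most of those two earlier rises: a 5.8-fold lower number from compound 3 to compound 4 (0.76 log units; beyond the scatter) is the estimated step in this assay. Compound 4 is therefore expected near 3500 nM, within 1500 nM to 8000 nM.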

Compound 4, half-maximal inhibitory concentration: 2870 nM
Compound 4: the middle estimate sits 1.2-fold (0.09 log units) above what was measured; the range from low to high includes it.
By their numbers in this assay, from the lowest: compounds 4, 1 and 2 (each within the scatter of the next); then compound 3.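

In this assay, a 7.1-fold lower number from compound 3 to compound 4 (0.85 log units; beyond the scatter) shows that the high number of compound 3 goes with its 3,4,5-trimethoxyphenyl and not with substitution of the phenyl as such. Bromo, isopropyl and hydrogen cannot be told apart here, with a 1.2-fold lower number from compound 1 to compound 4 (0.07 log units; within the scatter) and a 1.2-fold lower number from compound 2 to compound 4 (0.09 log units; within the scatter) both within the scatter, so among these four compounds only the 3,4,5-trimethoxyphenyl stands apart. Nothing available explains this difference. Still open, going by these compounds, is whether a single methoxy group on the phenyl raises the number, and how an amine or a carboxylic acid there would read.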